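Series notes: from the hydroxy compound to its aminoalkyl ether

The compounds below may be only part of what the source reports. "The series", "measured", "known", "first", "only" and "open" are said of these compounds alone.

Compound 2 `COc1cc(/C=C/C(=O)Nc2ccccc2)ccc1O` carries the free hydroxy group. For the measured compounds named here, in a physicochemical assay for lipophilicity, using the shake flask method, measured as octanol-water partition, at pH 7.4 (on this read-out higher numbers stand for higher lipophilicity and lower numbers for lower lipophilicity), compound 2 gives 1.42; the only other number, for compound 1 `COc1cc(/C=C/C(=O)Nc2ccccc2)ccc1OCCCN1CCCC1`, lies within the scatter of it. In this assay compound 1 gives 1.57. Going by the values given here, the one measured step, a number 0.15 log units lower from compound 1 to compound 2 (within the scatter), bears directly on the change now at hand, since compound 3 `COc1cc(/C=C/C(=O)Nc2ccccc2)ccc1OCCCCCN(C)C` differs by 5-(dimethylamino)pentyl in place of hydrogen on an oxygen on an aromatic ring. That step stayed within the scatter, so the expected step here is a number 0.28 log units higher from compound 2 to compound 3 (within the scatter), with no movement beyond the scatter anticipated. Compound 3 is estimated at 1.7, between 1.2 and 2.3.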

Compound 3, partition coefficient: 1.61
Estimate against measurement, compound 3: 0.09 log units above, within the range that was stated.
By their numbers in this assay, from the lowest: compounds 2, 1 and 3 (each within the scatter of the next).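

In this assay a second aminoalkyl ether on this oxygen on an aromatic ring shows a number 0.19 log units higher from compound 2 to compound 3 (within the scatter) and so stays within the scatter like the first. The reading a number 0.04 log units higher from compound 1 to compound 3 (within the scatter) adds that the two ethers cannot be told apart, although chain and amine end differ together. No evidence on hand bears on this result.

Still open, from the compounds shown here alone, is whether a carboxylic acid or a plain butyl chain on this oxygen would also stay within the scatter of compound 2.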